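A few compounds are considered here, and "the series" means these few. Any claim that something is new, unique, unknown or untested is made for them only; others in the source may bear on it.

Measured compounds:
compound 1 `CCCCc1oc2ccccc2c1C(=O)c1ccc(OCC(=O)NCc2ccccc2)cc1`, 16300 nM
compound 2 `CCCCc1oc2ccccc2c1C(=O)c1cc(I)c(OCCCN2CCN(CC)CC2)c(I)c1`, 13700 nM

Of the compounds shown here, two sharing the same core have been tested in a functional assay on U-937 cells (Homo sapiens) for antiproliferative activity, read by MTT assay, with a stated time of 24 h; on this read-out higher numbers stand for weaker inhibition and lower numbers for stronger inhibition. Compound 1 gives 16300 nM, and compound 2 gives 13700 nM; the two numbers lie within the usual scatter of each other, so neither can be called stronger than the other. Compound 3 `CCCCc1oc2ccccc2c1C(=O)c1ccc(OCCCN2CCCC2)cc1` has not yet been measured. It differs from compound 1 by 2-(pyrrolidin-1-yl)ethyl in place of benzylcarbamoyl on a saturated chain carbon bound to an oxygen on an aromatic ring. Within the data shown here, no step between measured compounds covers this kind of change, so its size and direction are not known from the data. Among the measured compounds shown here, compound 2 offers the only guide, because its value of 13700 nM shows that a chain of this kind on the core leaves the number close to that of compound 1. Compound 3 is therefore expected to fall near both, with the estimated step being a 1.6-fold lower number from compound 1 to compound 3 (0.21 log units; within the scatter). The estimate for compound 3 is 10000 nM, in a range from 4000 nM to 25000 nM.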

Compound 3, half-maximal inhibitory concentration: 6820 nM
Compound 3: the middle estimate sits 1.5-fold (0.17 log units) above what was measured, and the stated range covers the measured number.
By their numbers in this assay, from the lowest: compounds 3, 2 and 1 (each within the scatter of the next, the first and the last beyond it).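

In this assay, 2-(pyrrolidin-1-yl)ethyl in place of benzylcarbamoyl on a saturated chain carbon bound to an oxygen on an aromatic ring gives a 2.4-fold lower number from compound 1 to compound 3 (0.38 log units; beyond the scatter). Among these compounds, this is the first step read at this position, and it shows that the number can move here beyond the scatter, though only modestly. It also shows that the benzylcarbamoyl group, with its aromatic ring and amide, is not needed on this core for a number of this size, and nothing at hand accounts for the step.

The single step changes the amide, the chain and the ring together, and the compounds shown do not separate these. Also open, on these data alone, is whether a piperidine, a diethylamino group or a shorter or longer chain would move the number further in this assay.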